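A few compounds are considered here, and "the series" means these few. Any claim that something is new, unique, unknown or untested is made for them only; others in the source may bear on it.

Measured in a functional assay on HeLa cells (Homo sapiens) for inhibition, read by CCK-8 assay, with a stated time of 48 h; a lower number here means a stronger inhibitor, a higher number a weaker inhibitor:
- compound 1 `O=C(NCCNS(=O)(=O)c1ccc(-c2ccccc2OCc2cccc(O)c2)s1)Nc1cc(Cl)cc(Cl)c1`: > 50000 nM
- compound 2 `O=C(NCCNS(=O)(=O)c1ccc(-c2ccccc2OCc2ccccc2)s1)Nc1cc(Cl)cc(Cl)c1`: > 20000 nM

Both entries are limits of the assay, not numbers. Compound 1 therefore has a position only as the limit > 50000 nM in this assay.

Compound 3 `O=[N+]([O-])c1cccc(NC(=S)NCCNS(=O)(=O)c2ccc(-c3ccccc3OCc3cccc(O)c3)s2)c1` changes the group on an amine nitrogen, where the (3,5-dichlorophenyl)carbamoyl group leaves: a group of 12 heavy atoms (7 carbon, 2 nitrogen, 2 oxygen, 1 sulfur; one six-membered aromatic ring of carbon only) in place of a group of 11 heavy atoms (7 carbon, 1 nitrogen, 1 oxygen, 2 chlorine; one six-membered aromatic ring of carbon only), on an amine nitrogen.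

Within the data shown here, the only measured step, a step that the two limits leave unreadable from compound 1 to compound 2, is hydrogen in place of hydroxy on an aromatic carbon. It does not touch that amine nitrogen and gives no size to carry over. Compound 1 offers only its limit > 50000 nM as an anchor, so a weak result with no firm direction of change is expected.

The expected step is an at least 1.6-fold lower number from compound 1 to compound 3 (0.22 log units; that floor lies within the scatter), an estimate resting on a limit. For compound 3 the estimate is 30000 nM, with an expected range of 8000 nM to 80000 nM.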

Compound 3, half-maximal inhibitory concentration: 11100 nM
The estimate for compound 3 lay 2.7-fold (0.43 log units) above the measured number, and the stated range covers the measured number.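

In this assay, the change on the amine nitrogen gives the only readable step in the series: an at least 4.5-fold lower number from compound 1 to compound 3 (0.65 log units; beyond the scatter), and compound 3 is the only compound shown with a measured number rather than a limit. The step is a floor, and the change replaces the (3,5-dichlorophenyl)carbamoyl group with a group that brings in sulfur and a nitro group and loses both chlorines, so this single comparison cannot assign the gain to any one of these features. Nothing measured here gives a cause for the change.

Still open, as far as these compounds go, is which feature carries the step, which a 3,5-dichlorophenyl group on the sulfur-bearing linkage or a nitrophenyl group on the carbamoyl linkage would separate. From the compounds shown here alone, the step between the two limits cannot be read, so the role of the hydroxy group also stays open, and an amine or a carboxylic acid at that place would test it only if the values fall within the range of the assay.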